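Bromophenyl and Amine Ring Swaps in a Cytotoxicity Series

The source may hold more compounds than are shown below. What is called first, only, known or untested is meant among the compounds shown, and "the series" means these compounds.

Compound 1 `COc1cc2c(Oc3ccc(NC(=O)c4nn(-c5ccc(Br)cc5)c(=O)c5ccccc45)cc3F)ccnc2cc1OCCCN1CCCC1` is the reference point of this small set. In a functional assay on HT-29 cells (Homo sapiens) for cytotoxicity, read by MTT assay, with a stated time of 72 h (on this read-out lower numbers stand for stronger inhibition and higher numbers for weaker inhibition), compound 1 gives 670 nM. Compound 2 `COc1cc2c(Oc3ccc(NC(=O)c4nn(-c5ccccc5Br)c(=O)c5ccccc45)cc3F)ccnc2cc1OCCCN1CCCC1` differs from it in one place, (2-bromophenyl in place of 4-bromophenyl on an aromatic nitrogen), and in this assay compound 2 gives 850 nM, a step of a 1.3-fold higher number from compound 1 to compound 2 (0.10 log units; within the scatter). Compound 3 `COc1cc2c(Oc3ccc(NC(=O)c4nn(-c5ccc(Br)cc5)c(=O)c5ccccc45)cc3F)ccnc2cc1OCCCN1CCC(C)CC1` keeps the 4-bromophenyl group but changes the core, (4-methylpiperidin-1-yl in place of pyrrolidin-1-yl on a saturated chain carbon, three bonds along the chain from an oxygen on an aromatic ring); in this assay compound 3 gives 920 nM, a step of a 1.4-fold higher number from compound 1 to compound 3 (0.14 log units; within the scatter). Compound 4 `COc1cc2c(Oc3ccc(NC(=O)c4nn(-c5ccccc5Br)c(=O)c5ccccc45)cc3F)ccnc2cc1OCCCN1CCC(C)CC1` has not yet been tested. It stands to compound 3 as compound 2 stands to compound 1: the change is 2-bromophenyl in place of 4-bromophenyl on an aromatic nitrogen, at a place described in the same terms for both pairs, so it is the same change made on the core of compound 3. Within the data shown here, the one measured instance of this change is small and within the scatter. On that basis the step from compound 3 to compound 4 in this assay is expected to be about a 1.3-fold higher number from compound 3 to compound 4 (0.12 log units; within the scatter), because the earlier instance gave a 1.3-fold higher number from compound 1 to compound 2 (0.10 log units; within the scatter). Compound 4 is therefore estimated to give 1200 nM, with a likely range from 600 nM to 2400 nM.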

Compound 4, half-maximal inhibitory concentration: 950 nM
Beside the measured number, compound 4's estimate is 1.3-fold (0.10 log units) above it; low and high end bracket the measured number.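

In this assay, 2-bromophenyl in place of 4-bromophenyl on the core of compound 3 gives a 1.0-fold higher number from compound 3 to compound 4 (0.01 log units; within the scatter) and reads alike beside the earlier instance: the same change on two cores in this assay, a 1.3-fold higher number (0.10 log units; within the scatter) from compound 1 to compound 2 and a 1.0-fold higher number (0.01 log units; within the scatter) from compound 3 to compound 4, 1.2-fold (0.09 log units) apart, within the scatter of two such steps.
The swap of 4-methylpiperidin-1-yl in place of pyrrolidin-1-yl gives a 1.1-fold higher number from compound 2 to compound 4 (0.05 log units; within the scatter) and also reads alike on both cores: the same change on two cores in this assay, a 1.4-fold higher number (0.14 log units; within the scatter) from compound 1 to compound 3 and a 1.1-fold higher number (0.05 log units; within the scatter) from compound 2 to compound 4, 1.2-fold (0.09 log units) apart, within the scatter of two such steps.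
Among these compounds, neither change moves the number beyond the scatter on either core, and the two changes carry across these cores without a visible difference; with steps this small, however, this shows only that both changes are quiet here, not that a larger effect would carry over or that other cores would behave the same way.

The compounds shown leave open whether a chlorophenyl or methoxyphenyl group in place of the bromophenyl would shift the number beyond the scatter. They also leave open what a morpholine or a dimethylamino group in place of the ring amines, or a longer chain to the amine, would do.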